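Diallylamino Replaces Butyl(methyl)amino on the Sulfonyl Sulfur

A few compounds are considered here, and "the series" means these few. Any claim that something is new, unique, unknown or untested is made for them only; others in the source may bear on it.

In an assay on liver for inhibition of sterol O-acyltransferase 1 (Rattus norvegicus), using microsomes (on this read-out lower numbers stand for stronger inhibition and higher numbers for weaker inhibition), compound 2 `CCCCN(C)S(=O)(=O)NC(=O)Nc1c(C(C)C)cccc1C(C)C` gives 2300 nM; compound 1 `CCN(CC)S(=O)(=O)NC(=O)Nc1c(C(C)C)cccc1C(C)C` gives 2500 nM, and the two sit within the scatter of each other. Within the data shown here, the one step known here, a 1.1-fold lower number from compound 1 to compound 2 (0.04 log units; within the scatter), exchanged the amine on the sulfonyl sulfur without moving the number. Compound 3 `C=CCN(CC=C)S(=O)(=O)NC(=O)Nc1c(C(C)C)cccc1C(C)C` differs from compound 2 by diallylamino in place of butyl(methyl)amino on a sulfonyl sulfur. Because a 1.1-fold lower number from compound 1 to compound 2 (0.04 log units; within the scatter) stayed within the scatter, the expected step of no change at the digits printed from compound 2 to compound 3 (within the scatter) is none beyond the scatter. Compound 3 is estimated at 2300 nM, with a range from 1000 nM to 5500 nM.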

Compound 3, half-maximal inhibitory concentration: 2700 nM
Compound 3: the middle estimate sits 1.2-fold (0.07 log units) below what was measured; measured number inside the range.
By their numbers in this assay, from the lowest: compounds 2, 1 and 3 (each within the scatter of the next).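

In this assay the diallylamino group, which brings two double bonds outside aromatic rings to the sulfonyl sulfur, leaves the number in place (a 1.2-fold higher number from compound 2 to compound 3 (0.07 log units; within the scatter)) and (a 1.1-fold higher number from compound 1 to compound 3 (0.03 log units; within the scatter)), both steps within the scatter. Among these three amines, then, double bonds in the chains produce no step beyond the scatter, a change the earlier pair did not test. Nothing available explains why the number holds. Still open, from the compounds shown here alone, is whether a piperidine ring, a carboxylic acid on the chain or longer chains such as dihexylamino would move the number beyond the scatter.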